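The compounds below may be only part of what the source reports. "The series", "measured", "known", "first", "only" and "open" are said of these compounds alone.

Compound 2 `NCCCCCCCCNC(=O)[C@H]1OC(n2cnc3c(N)ncnc32)[C@H](O)[C@@H]1O` shows the lower of the two numbers measured in an assay on cell membranes for binding affinity to 2-oxoglutarate receptor 1 (Rattus norvegicus), read by radioligand binding (on this read-out lower numbers stand for stronger inhibition and higher numbers for weaker inhibition), giving 29 nM, while compound 1 `CCCCCCCCCCCCNC(=O)[C@H]1OC(n2cnc3c(N)ncnc32)[C@H](O)[C@@H]1O` gives 163 nM. Compound 3 `CC(=O)NCCNC(=O)[C@H]1OC(n2cnc3c(N)ncnc32)[C@H](O)[C@@H]1O` has acetamido in place of 6-aminohexyl on a saturated chain carbon, two bonds along the chain from an amide-type nitrogen. Among the compounds with values here, the one measured step, a 5.6-fold lower number from compound 1 to compound 2 (0.75 log units; beyond the scatter), concerns adding a terminal amine to a long chain, not shortening the chain and capping that amine, so it bears on the new change only loosely. Since the free amine and the long chain are both lost, a weaker result is expected, a step of an 8.6-fold higher number from compound 2 to compound 3 (0.94 log units; beyond the scatter), with compound 3 estimated at 250 nM, between 60 nM and 1000 nM.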

Compound 3, inhibition constant: 46 nM
The estimate for compound 3 lay 5.4-fold (0.74 log units) above the measured number; measured number below the stated range.
By their numbers in this assay, from the lowest: compounds 2 and 3 (each within the scatter of the next); then compound 1.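

In this assay, replacing 6-aminohexyl with acetamido, on a saturated chain carbon, two bonds along the chain from an amide-type nitrogen, gives a 1.6-fold higher number from compound 2 to compound 3 (0.20 log units; within the scatter). A long chain and a free terminal amine are therefore not both needed for a number in this range, and acetamido in place of decyl gives a 3.5-fold lower number from compound 1 to compound 3 (0.55 log units; beyond the scatter). No evidence here explains this result.

On these data alone, it remains open how a free amine on the shorter chain would compare with acetamido. The effect of a carboxylic acid at the chain end is also unknown.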